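Methoxy to trifluoromethoxy: working notes on the series

This account rests on a few compounds, and the source may have more. Where it says the series, first, only, none or still open, it means among the compounds named here.

- compound 1 `CCC1=C(O)c2c(oc(-c3ccc(O)cc3)cc2=O)C(CC)(CC)C1=O` gives 20.6 uM as measured
- compound 2 `CCC1=C(O)c2c(oc(-c3ccc(OC)cc3)cc2=O)C(CC)(CC)C1=O` gives 17.7 uM as measured

Both numbers come from a functional assay on KB cells (Homo sapiens) for antiproliferative activity, read by sulforhodamine B assay, with a stated time of 3 days (a lower number here means that less compound is needed, a higher number that more compound is needed for the effect), and compound 2 sits within the scatter of compound 1, so neither ranks ahead. Compound 3 `CCC1=C(O)c2c(oc(-c3ccc(OC(F)(F)F)cc3)cc2=O)C(CC)(CC)C1=O` has trifluoromethyl in place of methyl on an oxygen on an aromatic ring relative to compound 2. For the measured compounds named here, the only measured change on that oxygen is methyl in place of hydrogen, a 1.2-fold lower number from compound 1 to compound 2 (0.07 log units; within the scatter) and one step is thin support. No step beyond the scatter is therefore expected in this assay and the estimated step is a 1.1-fold lower number from compound 2 to compound 3 (0.04 log units; within the scatter) for now. Compound 3 is expected at 16 uM within an estimated range of 7 uM to 35 uM in this series.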

Compound 3, concentration for half-maximal effect: 36.5 uM
The estimate for compound 3 lay 2.3-fold (0.36 log units) below the measured number; measured number above the stated range.
By their numbers in this assay, from the lowest: compounds 2, 1 and 3 (each within the scatter of the next, the first and the last beyond it).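

For the compounds shown here, on the oxygen on the aromatic ring, trifluoromethyl in place of methyl gives the first step at this position to pass the scatter in this assay (a 2.1-fold higher number from compound 2 to compound 3 (0.31 log units; beyond the scatter)), and that step is modest. Trifluoromethyl in place of hydrogen stays within the scatter (a 1.8-fold higher number from compound 1 to compound 3 (0.25 log units; within the scatter)), so the reading depends on which pair is compared. Nothing at hand bears on the cause of the step.

Open, on these data alone, is where an ethyl or longer chain on this oxygen would fall relative to compound 2 and compound 3. As far as these compounds go, an amine in place of the oxygen is equally open.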